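Ether to furan ester on a shared naphthoquinone-bearing core

The compounds below may be only part of what the source reports. "The series", "measured", "known", "first", "only" and "open" are said of these compounds alone.

Compound 1 `CCCCC(CC(=O)O[C@H](CC=C(C)C)C1=CC(=O)c2c(O)ccc(O)c2C1=O)OC(C)=O`: 73500 nM
Compound 2 `CC(=O)OC(C)CO[C@H](CC=C(C)C)C1=CC(=O)c2c(O)ccc(O)c2C1=O`: 40100 nM

In a functional assay on HeLa cells (Homo sapiens) for cytotoxicity, read by MTT assay (on this read-out higher numbers stand for weaker inhibition and lower numbers for stronger inhibition), compound 2 gives the lower of the two numbers, and compound 1 sits close to it, within the scatter. Compound 3 `CC(C)=CC[C@@H](OC(=O)c1ccoc1)C1=CC(=O)c2c(O)ccc(O)c2C1=O` is the unmeasured partner, carrying a (furan-3-yl)carbonyl in place of the 2-acetoxypropyl on an oxygen on a saturated carbon ((furan-3-yl)carbonyl in place of 2-acetoxypropyl on an oxygen on a saturated carbon). Among the measured compounds shown here, no measured pair shows what such a swap does, so the step of a 1.1-fold higher number from compound 2 to compound 3 (0.05 log units; within the scatter) is expected to be small, in no fixed direction, and likely within the scatter. Compound 3 is therefore estimated at 45000 nM, with a range from 15000 nM to 130000 nM.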

Compound 3, half-maximal inhibitory concentration: > 100000 nM
Compound 3: no number, only a limit; the forecaster's own chance of this, stated with the estimate: 15%; at least 2.2-fold (0.34 log units) between middle value and limit.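

In this assay compound 3 gives > 100000 nM, which is a limit of the assay and not a number. Putting (furan-3-yl)carbonyl in place of 2-acetoxypropyl on this oxygen gives an at least 2.4-fold higher number from compound 2 to compound 3 (0.39 log units; beyond the scatter), so the position does respond to the group it carries. With furan-3-yl in place of 2-acetoxyhexyl on a carbonyl carbon, the result is an at least 1.3-fold higher number from compound 1 to compound 3 (0.13 log units; that floor lies within the scatter), and both steps remain floors: the limit of > 100000 nM in this assay, at which 1 of the 3 values shown sits.

On these data alone, how far compound 3 truly lies from the other two stays open. So does whether an amine, a carboxylic acid or a longer chain on this oxygen would give a lower number in this assay.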